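A Fluorinated Ring on the Sulfur

The compounds below may be only part of what the source reports. "The series", "measured", "known", "first", "only" and "open" are said of these compounds alone.

In a functional assay on HeLa cells (Homo sapiens) for inhibition, read by CCK-8 assay, with a stated time of 72 h, tested at 8 uM (on this read-out lower numbers stand for less inhibition of growth and higher numbers for more inhibition of growth at the one concentration tested), compound 2 (`Nc1ccccc1NC(=O)c1ccc(CSCCc2ccccc2)cc1`) gives 74.8% of inhibition, within the scatter of compound 1 (`COc1ccc(SCc2ccc(C(=O)Nc3ccccc3N)cc2)cc1`), which gives 79.7% of inhibition. Compound 3 (`Nc1ccccc1NC(=O)c1ccc(CSc2ccc(F)cc2)cc1`) has 4-fluorophenyl in place of phenethyl on a sulfur. Within the data shown here, the only measured step at that sulfur, a number 4.9 percentage points lower from compound 1 to compound 2 (within the scatter) on exchanging 4-methoxyphenyl for phenethyl, stayed within the scatter. No step beyond the scatter is therefore expected in this assay for this new exchange. The expected change is a number 2.2 percentage points higher from compound 2 to compound 3 (within the scatter) in size, which is no more than scatter. Compound 3 is estimated at 77% of inhibition, with an expected range from 65% to 88% here.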

Compound 3, percent growth inhibition at one concentration: 79.3%
The estimate for compound 3 lay 2.3 percentage points below the measured number; measured number inside the range.
By their numbers in this assay, from the lowest: compounds 2, 3 and 1 (each within the scatter of the next).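

In this assay the exchange of phenethyl for 4-fluorophenyl on the sulfur gives a number 4.5 percentage points higher from compound 2 to compound 3 (within the scatter) and so stays inside the scatter, as the earlier exchange at this sulfur did. New here is a change on the ring itself: fluoro in place of methoxy on an aromatic carbon gives a number 0.4 percentage points lower from compound 1 to compound 3 (within the scatter) and also cannot be told apart from scatter at this single concentration. Going by these compounds, whether an amine or a carboxylic acid on that ring, or a longer chain on the sulfur, would move the number beyond the scatter remains open. No evidence here explains why these compounds read alike.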